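This account rests on a few compounds, and the source may have more. Where it says the series, first, only, none or still open, it means among the compounds named here.

Measured compounds:
- compound 1, `N#C/C(=C\c1c[nH]c2ccccc12)C(=O)c1c[nH]c2ccccc12`, gives 13000 nM
- compound 2, `COc1ccc(CNC(=O)/C(C#N)=C/c2ccco2)cc1`, gives 31000 nM

On a functional assay on SJ-G2 cells (Homo sapiens) for inhibition, read by MTT assay, with a stated time of 72 h (on this read-out lower numbers stand for stronger inhibition of growth and higher numbers for weaker inhibition of growth), compound 2 holds the higher of the two numbers, and compound 1 stands at a lower number by a gap beyond the usual scatter. Compound 3, `COc1ccc(CNC(=O)/C(C#N)=C/c2ccc(-c3ccccc3)o2)cc1`, differs from compound 2 by phenyl in place of hydrogen on an aromatic carbon. Within the data shown here, no measured pair differs in one place, so no reference step exists for this change. He expects for compound 3 a modest step toward a lower number, a 2.1-fold lower number from compound 2 to compound 3 (0.32 log units; beyond the scatter), though it could equally fall within the scatter. His estimate for compound 3 in this assay is 15000 nM, with a range from 5000 nM to 50000 nM.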

Compound 3, concentration for 50% growth inhibition: > 100000 nM
Compound 3 gave a limit, no number; the forecaster's own chance of this, stated with the estimate: 10%; middle value at least 6.6-fold (0.82 log units) from the limit.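

Phenyl in place of hydrogen on an aromatic carbon, next to the ring oxygen, is the only single-place change shown, and in this assay it gives an at least 3.2-fold higher number from compound 2 to compound 3 (0.50 log units; beyond the scatter) on this read-out, meaning weaker inhibition of growth. At this position, then, phenyl brings no gain over hydrogen. Compound 3 gives a limit, not a number: the limit of > 100000 nM in this assay, at which 1 of the 3 values shown sits.

On these data alone, how far compound 3 lies beyond that limit stays open. So does whether methyl, an amine or a carboxylic acid at this position would give a lower number than phenyl.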